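Ester tail changes and human microsomal half-life

A few compounds are considered here, and "the series" means these few. Any claim that something is new, unique, unknown or untested is made for them only; others in the source may bear on it.

Three members of the series carry the shared core with a cinnamate-type ester whose oxygen substituent varies. Compound 1 `CCOc1cc(NC(=O)C2(NC(=O)c3ccc4c(C5CCCC5)c(-c5ncc(Cl)cn5)n(C)c4c3)CCC2)ccc1/C=C/C(=O)OC(=O)C[C@H](O)C(=O)O` gives 5.57 h in an ADME assay (liver) for pharmacokinetics, with Liver microsome (Homo sapiens) as the target, using microsomes; a lower number here means that the compound disappears faster, a higher number that the compound lasts longer. Compound 2 `CCCOC(=O)/C=C/c1ccc(NC(=O)C2(NC(=O)c3ccc4c(C5CCCC5)c(-c5ncc(Cl)cn5)n(C)c4c3)CCC2)cc1OCC` gives > 5 h in this assay, which is a limit of the assay and not a number (the limit of > 5 h in this assay, at which 1 of the 3 values shown sits). Compound 3 `CCOc1cc(NC(=O)C2(NC(=O)c3ccc4c(C5CCCC5)c(-c5ncc(Cl)cn5)n(C)c4c3)CCC2)ccc1/C=C/C(=O)OCCOCCOC` gives 0.85 h in this assay; among the two numbers it stands lowest, with compound 1 nearest at a 6.6-fold lower number from compound 1 to compound 3 (0.82 log units; beyond the scatter). The step of an at least 5.8-fold lower number from compound 2 to compound 3 (0.76 log units; beyond the scatter) runs in the same direction, though read against a limit.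

Compound 4 `CCOc1cc(NC(=O)C2(NC(=O)c3ccc4c(C5CCCC5)c(-c5ncc(Cl)cn5)n(C)c4c3)CCC2)ccc1/C=C/C(=O)OCC(=O)N1CCOCC1` replaces the ether chain of compound 3: (morpholin-4-yl)carbonyl in place of (2-methoxyethoxy)methyl on a saturated chain carbon bound to an oxygen next to a carbonyl group. The steps bearing on this change both involve the 2-(2-methoxyethoxy)ethyl tail of compound 3, namely a 6.6-fold lower number from compound 1 to compound 3 (0.82 log units; beyond the scatter) and an at least 5.8-fold lower number from compound 2 to compound 3 (0.76 log units; beyond the scatter), and both lowered the number by a modest amount. Going by the values given here, removing the (2-methoxyethoxy)methyl piece may recover part of that loss, but the incoming (morpholin-4-yl)carbonyl has no measured counterpart here, so the size is uncertain. A modest rise is expected, a 2.4-fold higher number from compound 3 to compound 4 (0.37 log units; beyond the scatter). Compound 4 is therefore estimated at 2 h, within a range of 0.7 h to 5.5 h.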

Compound 4, half-life: 0.667 h
For compound 4 the middle estimate is 3.0-fold (0.48 log units) above the measured one, and the stated range ends above it.
By their numbers in this assay, from the lowest: compounds 4 and 3 (each within the scatter of the next); then compound 1.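

In this assay, putting (morpholin-4-yl)carbonyl in place of (2-methoxyethoxy)methyl on a saturated chain carbon bound to an oxygen next to a carbonyl group gives a 1.3-fold lower number from compound 3 to compound 4 (0.11 log units; within the scatter), so the ring-bearing tail and the open ether tail cannot be told apart at this position. The step of an 8.4-fold lower number from compound 1 to compound 4 (0.92 log units; beyond the scatter) is close in size to the one already seen for the ether tail of compound 3, which shows that the gap to compound 1 is not confined to the 2-(2-methoxyethoxy)ethyl tail. The step of an at least 7.4-fold lower number from compound 2 to compound 4 (0.87 log units; beyond the scatter) points the same way but is read against a limit of the assay held by compound 2, not a number: the limit of > 5 h in this assay, at which 1 of the 4 values shown sits.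

Going by these compounds, with only four tails in hand, it remains open whether the gap to compounds 1 and 2 follows from the chain length, the ether oxygens or the morpholine ring, and a butyl chain or a 2-methoxyethyl tail would help to separate these. A 2-(dimethylamino)ethyl tail, which carries an amine, would show whether the half-life at this position also responds to a basic nitrogen.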